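Compound 3: a new aryl group on the piperazine

The source may report more compounds than this note shows. Statements on the series, on what has been measured and on what is new or still open speak of the compounds shown alone.

Measured so far in a functional assay on HL-60 cells (Homo sapiens) for inhibition, read by MTT assay, with a stated time of 72 h (on this read-out lower numbers stand for stronger inhibition and higher numbers for weaker inhibition), for two compounds:
- compound 1 `Cc1nc(-c2ccccc2F)c(C(=O)N2CCN(c3cc(Cl)ccc3C)CC2)o1` with 229 nM as its value
- compound 2 `Cc1ccc(C)c(N2CCN(C(=O)c3oc(C)nc3-c3cccc(Cl)c3)CC2)c1` with 345 nM as its value

Compound 1 stands within the scatter of compound 2, so neither can be ranked ahead. Compound 3 `COc1cc(OC)cc(N2CCN(C(=O)c3oc(C)nc3-c3ccccc3F)CC2)c1` keeps the core of compound 1 but carries 3,5-dimethoxyphenyl in place of 5-chloro-2-methylphenyl on an amine nitrogen in a ring, a change counted as 3,5-dimethoxyphenyl in place of 5-chloro-2-methylphenyl on an amine nitrogen in a ring here. Among the compounds with values here, no measured pair isolates such a change, so only a small weakening in this assay is expected, perhaps none beyond the scatter. The expected change is a 1.7-fold higher number from compound 1 to compound 3 (0.24 log units; within the scatter) on this estimate. Compound 3 is estimated at 400 nM with an expected range from 120 nM to 1300 nM in this read-out.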

Compound 3, half-maximal inhibitory concentration: 10.3 nM
Compound 3: the middle estimate sits 39-fold (1.59 log units) above what was measured; the measured number lies below the stated range.
By their numbers in this assay, from the lowest: compound 3; then compounds 1 and 2 (each within the scatter of the next).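

In this assay the swap of 5-chloro-2-methylphenyl for 3,5-dimethoxyphenyl on an amine nitrogen in a ring gives a 22-fold lower number from compound 1 to compound 3 (1.35 log units; beyond the scatter) and so shows that this position can move the read-out strongly, which compound 1 and compound 2, lying within the scatter of each other, did not show. Nothing measured here says which part of the change accounts for the step.

On these data alone, it remains open whether a single methoxy group would carry the step, and whether an amine or a carboxylic acid in place of the methoxy groups would keep it.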